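The source may report more compounds than this note shows. Statements on the series, on what has been measured and on what is new or still open speak of the compounds shown alone.

Among the compounds with values here, in a toxicity assay on NIH3T3 cells (Mus musculus) for cytotoxicity, read by resazurin assay (a lower number here means that less compound is needed, a higher number that more compound is needed for the effect), compound 2 `COC(=O)c1ccc(NCc2cncn2Cc2ccccc2N)cc1-c1ccccc1` gives 25000 nM, the only plain number among the three values reported. Compound 1 `c1ccc(-c2ccc(Cn3cncc3CNc3ccc(-c4onc5ccccc45)c(-c4ccccc4)c3)cc2)cc1` gives only a limit of the assay, > 10000 nM. Compound 3 `Cc1ccccc1-c1cc(NCc2cncn2Cc2ccc(-c3ccccc3)cc2)ccc1-c1nc2ccccc2s1` likewise gives only a limit of the assay, > 1000 nM. The two limits sit at the limit of > 1000 nM in this assay, at which 1 of the 3 values shown sits, and (the limit of > 10000 nM in this assay, at which 1 of the 3 values shown sits), so compound 2 stands alone as the compound with a measured number. Compound 4 `COC(=O)c1ccc(NCc2cncn2Cc2ccccc2C#N)cc1-c1ccccc1` has not yet been tested in this assay. It differs from compound 2 by cyano in place of amino on an aromatic carbon. Within the data shown here, no step between measured compounds is available, so no measured size of change exists for this kind of exchange. Compound 4 is expected to stay close to compound 2, with a step of no change at the digits printed from compound 2 to compound 4 (within the scatter) that remains within the scatter. The estimate for compound 4 is 25000 nM, expected to fall between 8000 nM and 80000 nM.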

Compound 4, half-maximal effective concentration: 25000 nM
Compound 4: middle estimate and measured number agree at the digits printed, within the range that was stated.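

In this assay, the exchange at this position, on an aromatic carbon ortho to a large group, gives no change at the digits printed from compound 2 to compound 4 (within the scatter). This is the only step shown with a plain number at both ends, and it shows that 2-aminobenzyl and 2-cyanobenzyl are not separated by this read-out, even though the hydrogen-bond donor of the amino is absent from the cyano. No measured property shown here bears on this result. The compounds shown leave open how a carboxylic acid or a dimethylamino group would read at this position, and whether the same exchange would read alike on another core.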